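This account rests on a few compounds, and the source may have more. Where it says the series, first, only, none or still open, it means among the compounds named here.

Working notes on the series. In a functional assay on MCF7 cells (Homo sapiens) for cytotoxicity, read by sulforhodamine B assay, with a stated time of 48 h (a lower number here means a stronger inhibitor of growth, a higher number a weaker inhibitor of growth), compound 1 `COC(=O)c1[nH]c2ccc(Cl)cc2c1C(=O)c1cc(OC)c(OC)c(OC)c1N` gives 171 nM. Compound 2 `COC(=O)c1[nH]c2ccc(Br)cc2c1C(=O)c1cc(OC)c(OC)c(OC)c1N` differs from it only by bromo in place of chloro on an aromatic carbon; in this assay compound 2 gives 124 nM, and the step of a 1.4-fold lower number from compound 1 to compound 2 (0.14 log units; within the scatter). Compound 3 `COc1cc(Cc2c[nH]c3ccc(Cl)cc23)c(N)c(OC)c1OC` is built on a different core; the difference between the two cores is not broken down here. In this assay compound 3 is reported as "not active" (no number reported), with no number given. Compound 4 `COc1cc(Cc2c[nH]c3ccc(Br)cc23)c(N)c(OC)c1OC` is related to compound 3 by bromo in place of chloro on an aromatic carbon, the same change as from compound 1 to compound 2, at the same place. Among the measured compounds shown here, only one measured instance of that change exists, and that instance lies within the scatter, so nothing here suggests that the change by itself would carry a compound from no measurable activity to a measurable number. Compound 4 is therefore expected to stand close to compound 3, most likely again without a reportable number. Should a number be obtained for compound 4, it is estimated around 30000 nM, between 8000 nM and 120000 nM.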

Compound 4, concentration for 50% growth inhibition: "not active" (no number reported)
Compound 4: no number reported, so the estimate cannot be set against anything.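

Compound 3 and compound 4 both come without a number, so no step can be read between them. No supporting data bear on this result. The compounds shown leave open whether bromo in place of chloro alters growth inhibition on the core of compound 3, since neither compound gives a value to compare.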